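Adding a Second Chloro to Compound 3

A few compounds are considered here, and "the series" means these few. Any claim that something is new, unique, unknown or untested is made for them only; others in the source may bear on it.

Measured so far in an in vitro functional assay on 1321-N1 cells for antagonist activity at transient receptor potential cation channel subfamily V member 1 (Homo sapiens), read by FLIPR and calcium flux; on this read-out lower numbers stand for stronger inhibition and higher numbers for weaker inhibition:
compound 1, `O=C(Nc1ccc(Cl)cc1)C1=CCN(c2ncccc2C(F)(F)F)CC1`: 19 nM
compound 2, `O=C(Nc1ccc(S(=O)(=O)C(F)(F)F)cc1)C1=CCN(c2ncccc2Cl)CC1`: 41 nM
compound 3, `O=C(Nc1ccc(Cl)cc1)C1=CCN(c2ncccc2Cl)CC1`: 33 nM

Compound 3 holds the second highest of these three numbers; closest to it is compound 2 with a 1.2-fold lower number from compound 2 to compound 3 (0.09 log units; within the scatter), and furthest is compound 1 with a 1.7-fold higher number from compound 1 to compound 3 (0.24 log units; within the scatter), both within the scatter. Compound 4, `O=C(Nc1ccc(Cl)c(Cl)c1)C1=CCN(c2ncccc2Cl)CC1`, differs from compound 3 by chloro in place of hydrogen on an aromatic carbon. Among the measured compounds shown here, neither measured step is of this kind: the steps from compound 1 and compound 2 to compound 3 each exchanged one group for another at an already substituted aromatic carbon and stayed within the scatter, and no step adds a group where a hydrogen stood. Without a direct precedent, the expected step of a 1.3-fold lower number from compound 3 to compound 4 (0.12 log units; within the scatter) in this assay is small and within the scatter. Compound 4 is therefore estimated at 25 nM, with a range from 8 nM to 80 nM.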

Compound 4, half-maximal inhibitory concentration: 124 nM
Compound 4: middle estimate off by 5.0-fold (0.70 log units), on the low side, outside the stated range (above it).
By their numbers in this assay, from the lowest: compounds 1, 3 and 2 (each within the scatter of the next, the first and the last beyond it); then compound 4.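

The added chloro brings a 3.8-fold higher number from compound 3 to compound 4 (0.57 log units; beyond the scatter) in this assay, the first step among these compounds to lie beyond the scatter. This aromatic carbon, ortho to a chloro group and meta to a large group, therefore does not accept chloro in place of hydrogen without weaker inhibition, whereas the exchanges at already substituted carbons stayed within the scatter. Nothing available accounts for this loss.

On these data alone, whether fluoro, methoxy or a nitrile at this carbon would cost as much remains open. So does whether the same chloro would cost as much in compound 1, which carries trifluoromethyl instead of the chloro on the pyridine side.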